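Compound 4: a brominated thiophene in place of dimethoxyphenyl

The source may hold more compounds than are shown below. What is called first, only, known or untested is meant among the compounds shown, and "the series" means these compounds.

Three measured compounds share one core and differ only in the group attached to the carbonyl carbon. Compound 1 `COc1ccc(-c2cc3ccccc3nc2/C=C/C(=O)c2ccc(OC)c(OC)c2)cc1` carries 3,4-dimethoxyphenyl there; in a functional assay on NCI-H1299 cells (Homo sapiens) for antiproliferative activity, read by XTT assay, with a stated time of 72 h (a higher number here means a weaker inhibitor, a lower number a stronger inhibitor), compound 1 gives 1050 nM, the highest of the three numbers. Compound 2 `COc1ccc(-c2cc3ccccc3nc2/C=C/C(=O)c2ccco2)cc1` carries furan-2-yl on that carbon and in this assay compound 2 gives 730 nM. Compound 3 `COc1ccc(-c2cc3ccccc3nc2/C=C/C(=O)c2cccs2)cc1` carries thiophen-2-yl, and in this assay compound 3 gives 720 nM. The steps between them are a 1.4-fold lower number from compound 1 to compound 2 (0.16 log units; within the scatter), a 1.5-fold lower number from compound 1 to compound 3 (0.16 log units; within the scatter) and a 1.0-fold lower number from compound 2 to compound 3 (0.01 log units; within the scatter), so all three values sit together within the scatter.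

Compound 4 `COc1ccc(-c2cc3ccccc3nc2/C=C/C(=O)c2ccc(Br)s2)cc1` has not yet been measured. Relative to compound 1 the change is 5-bromothiophen-2-yl in place of 3,4-dimethoxyphenyl on a carbonyl carbon. The measured step that bears on it most closely is a 1.5-fold lower number from compound 1 to compound 3 (0.16 log units; within the scatter), where thiophen-2-yl itself replaced the same group; the step of a 1.4-fold lower number from compound 1 to compound 2 (0.16 log units; within the scatter) tells the same story. Going by the values given here, the bromine on the entering group has no counterpart among the measured compounds, so nothing here speaks to it. The expectation for compound 4 is therefore a step of a 1.5-fold lower number from compound 1 to compound 4 (0.18 log units; within the scatter) in this assay, not beyond the scatter. Compound 4 is estimated at 700 nM, with a range from 300 nM to 1600 nM.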

Compound 4, half-maximal inhibitory concentration: 710 nM
Compound 4: middle estimate off by 1.0-fold (0.01 log units), on the low side; low and high end bracket the measured number.
By their numbers in this assay, from the lowest: compounds 4, 3, 2 and 1 (each within the scatter of the next).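

The new information lies in the bromo in place of hydrogen on an aromatic carbon of the thiophen-2-yl group: in this assay the step is a 1.0-fold lower number from compound 3 to compound 4 (0.01 log units; within the scatter), so adding this atom to the entering ring leaves the value where it was. The comparisons with the other two groups on the carbonyl carbon read the same way, with a 1.5-fold lower number from compound 1 to compound 4 (0.17 log units; within the scatter) and a 1.0-fold lower number from compound 2 to compound 4 (0.01 log units; within the scatter), so all four groups shown now sit within the scatter of one another in this assay. At this position, then, the assay does not separate a six-membered aromatic ring of carbon only from a five-membered aromatic ring with 1 hetero atom, whether or not that ring carries bromine.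

Nothing available bears on why the four values stay together. The compounds shown leave open whether a group of a different kind on the carbonyl carbon, such as a piperidine ring, a phenyl ring bearing a carboxylic acid or a longer alkyl chain, would give a step beyond the scatter, and whether a chlorine or a methyl in place of the bromine would matter.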